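The compounds below may be only part of what the source reports. "The series", "measured", "known", "first", "only" and "open" are said of these compounds alone.

For the measured compounds named here, compound 1 `O=C(CCCCC#Cc1ccccn1)c1ncc(-c2ccccn2)o1` sits highest of the three numbers so far: in an assay for inhibition of Fatty-acid amide hydrolase 1 (Rattus norvegicus) (on this read-out higher numbers stand for weaker inhibition and lower numbers for stronger inhibition), compound 1 gives 280 nM. The shared core and the linker are kept in the other two compounds while the group on the triple-bonded carbon changes. Compound 2 `O=C(CCCCC#Cc1cccc(Cl)c1Cl)c1ncc(-c2ccccn2)o1` gives 5 nM in this assay, with a 56-fold lower number from compound 1 to compound 2 (1.75 log units; beyond the scatter). Compound 3 `O=C(CCCCC#Cc1ccc([N+](=O)[O-])cc1)c1ncc(-c2ccccn2)o1` gives 31 nM in this assay, with a 9.0-fold lower number from compound 1 to compound 3 (0.96 log units; beyond the scatter), and between the two aryl variants a 6.2-fold higher number from compound 2 to compound 3 (0.79 log units; beyond the scatter).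

Compound 4 `O=C(CCCCCCc1ccccn1)c1ncc(-c2ccccn2)o1` keeps the pyridinyl group of compound 1 and changes the linker instead: 2-(pyridin-2-yl)ethyl in place of 2-(pyridin-2-yl)ethynyl on a saturated chain carbon, four bonds along the chain from a carbonyl carbon. Going by the values given here, none of the measured steps touches this linker; all three vary the ring on the triple-bonded carbon, so no step bears on the change from compound 1 to compound 4. Without a measured precedent, the expectation for compound 4 in this assay is a number close to that of compound 1, estimated as a 1.4-fold lower number from compound 1 to compound 4 (0.15 log units; within the scatter) in size. Compound 4 is expected to give about 200 nM in this assay, within a range of 50 nM to 800 nM.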

Compound 4, inhibition constant: 120 nM
Compound 4: middle estimate off by 1.7-fold (0.22 log units), on the high side; the measured number falls inside the stated range.
By their numbers in this assay, from the lowest: compound 2; then compound 3; then compound 4; then compound 1.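

Earlier steps varied only the ring on the triple-bonded carbon; this one shows that the linker also affects the number in this assay, with a 2.3-fold lower number from compound 1 to compound 4 (0.37 log units; beyond the scatter). With the pyridin-2-yl ring held constant, the triple bond is therefore not required for inhibition, and 2-(pyridin-2-yl)ethyl gives stronger inhibition than 2-(pyridin-2-yl)ethynyl in this single pair. No available evidence accounts for this difference.

On these data alone, whether the saturated linker would give a similar change with the 2,3-dichlorophenyl or 4-nitrophenyl group remains open, so the size of this step cannot be carried over to those rings. Also open, as far as these compounds go, is how a double bond in place of the triple bond, or a longer or shorter saturated chain, would compare with this pair.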